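The compounds below may be only part of what the source reports. "The series", "measured", "known", "first", "only" and "open" are said of these compounds alone.

Going by the values given here, in a physicochemical assay for lipophilicity, read by HPLC, measured as chromatographic lipophilicity, at pH 7.4 (a higher number here means a more lipophilic compound, a lower number a more polar compound), compound 1 `O=C(C1CCN(c2ncccn2)CC1)N1N=CC[C@H]1c1ccccc1` gives 4.7 as its distribution coefficient, the lower of the two numbers available so far. The other number belongs to compound 2 `CC(C)(C)C(=O)n1nccc1-c1ccccc1`, which gives 8.3 in the same measurement, and the gap between the two lies beyond the usual scatter. These two compounds differ in more than one place, so their gap cannot be assigned to any single change. The next compound to be measured is compound 3 `Cc1nnc(N2CCC(C(=O)N3N=CC[C@H]3c3ccccc3)CC2)o1`, which keeps the core of compound 1 and changes one group. It carries 5-methyl-1,3,4-oxadiazol-2-yl in place of pyrimidin-2-yl on an amine nitrogen in a ring and is otherwise the same. Among the compounds with values here, no measured pair differing in one place is available as a guide, so the expectation rests on the structural change alone. A downward step in this assay is expected, of a size beyond the scatter. The estimated step is a number 0.90 log units lower from compound 1 to compound 3 (beyond the scatter) and remains uncertain. For compound 3 the expected value is 3.8 within an estimated range from 3.2 to 4.4 on this scale.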

Compound 3, distribution coefficient: 3.2
Compound 3: the middle estimate sits 0.60 log units above what was measured; low and high end bracket the measured number.
By their numbers in this assay, from the lowest: compound 3; then compound 1; then compound 2.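

In this assay, going by these compounds alone, the change from pyrimidin-2-yl to 5-methyl-1,3,4-oxadiazol-2-yl on an amine nitrogen in a ring reads as a number 1.50 log units lower from compound 1 to compound 3 (beyond the scatter) and is the first difference in this set that can be tied to a single place. The two groups have the same count of heavy atoms and neither carries a net charge, yet this position, three ring bonds from the ring atom that bears a large group, still responds with a large step when a six-membered aromatic ring with 2 hetero atoms gives way to a five-membered aromatic ring with 3 hetero atoms. Nothing in the available data accounts for the size of this step.

A single step cannot separate the contribution of the ring from that of its methyl group, and a 1,3,4-oxadiazol-2-yl without the methyl or with an ethyl in its place would be needed to divide the two. As far as these compounds go, it also remains open whether other aromatic rings at this position, such as pyridin-2-yl or 1,3-thiazol-2-yl, would fall nearer compound 1 or compound 3 on this scale.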